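Branched Ether in Place of Cyclobutyl: What Compound 4 May Show

The source may hold more compounds than are shown below. What is called first, only, known or untested is meant among the compounds shown, and "the series" means these compounds.

Compound 1 `Nc1ccc2cccc(OC3CCC3)c2n1` is the point of departure. In an assay on cells with melanin-concentrating hormone receptor 1 (Homo sapiens) as the target, read by radioligand binding (a lower number here means a stronger inhibitor, a higher number a weaker inhibitor), compound 1 gives only a limit, > 2000 nM. Compound 2 `CCOCCOc1cccc2ccc(N)nc12` likewise reaches only a limit in this assay, > 2000 nM. Compound 3 `CC(C)OCCOc1cccc2ccc(N)nc12` also rests at a limit in this assay, > 2000 nM. The steps a step that the two limits leave unreadable from compound 1 to compound 2, a step that the two limits leave unreadable from compound 1 to compound 3 and a step that the two limits leave unreadable from compound 2 to compound 3 carry no readable size, since every value shown sits at the limit of > 2000 nM in this assay, at which 3 of the 3 values shown sit. Compound 4 `CC(C)C(C)Oc1cccc2ccc(N)nc12` differs from compound 1 by 1,2-dimethylpropyl in place of cyclobutyl on an oxygen on an aromatic ring. No measured step bears on this change, and no compound shown has yet come below the limit. Compound 4 is therefore expected to remain near the limit, estimated at 3000 nM within 1000 nM to 10000 nM. The implied step, a step that the limit leaves unreadable from compound 1 to compound 4, is expected to be of no readable size.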

Compound 4, half-maximal inhibitory concentration: 199 nM
Compound 4: middle estimate off by 15-fold (1.18 log units), on the high side; measured number below the stated range.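

For the compounds shown here, compound 4 is the first compound here to come off the limit in this assay, so the group on this oxygen can move the number: 1,2-dimethylpropyl gives an at least 10-fold lower number from compound 1 to compound 4 (1.00 log units; beyond the scatter). The same group also compares well with both ether chains, with an at least 10-fold lower number from compound 2 to compound 4 (1.00 log units; beyond the scatter) and an at least 10-fold lower number from compound 3 to compound 4 (1.00 log units; beyond the scatter). Each of these steps gives only a minimum size, and the full size stays unknown: the limit of > 2000 nM in this assay, at which 3 of the 4 values shown sit.

The compounds shown leave open whether the branching of 1,2-dimethylpropyl matters or any chain without an ether oxygen would serve. Going by these compounds, how an amine or a carboxylic acid on this chain would fare also remains open.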